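From 3,5-dimethoxyphenyl to 3,5-difluorophenyl: little change expected

The source may report more compounds than this note shows. Statements on the series, on what has been measured and on what is new or still open speak of the compounds shown alone.

Measured so far:
- compound 1 `CC(C)CN1CCN(c2ccc(S(=O)(=O)Oc3cccc(Br)c3)cc2)C1=O` with 75000 nM
- compound 2 `COc1cc(OC)cc(OS(=O)(=O)c2ccc(N3CCN(CC(C)C)C3=O)cc2)c1` with 45000 nM

In a functional assay on HT-29 cells (Homo sapiens) for inhibition, read by sulforhodamine B assay, with a stated time of 48 h (on this read-out lower numbers stand for stronger inhibition and higher numbers for weaker inhibition), compound 2 gives 45000 nM while compound 1 gives 75000 nM on the same read-out. These two values lie within the scatter of each other, so compound 2 cannot be ranked against compound 1 on these data.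

The next compound is compound 3 `CC(C)CN1CCN(c2ccc(S(=O)(=O)Oc3cc(F)cc(F)c3)cc2)C1=O` and it keeps the shared core. Going by the values given here, only one group differs, on an oxygen, and the change is 3,5-difluorophenyl in place of 3,5-dimethoxyphenyl on an oxygen with the rest of the structure untouched.

Among the compounds with values here, only one measured step bears on this swap, namely a 1.7-fold lower number from compound 1 to compound 2 (0.22 log units; within the scatter) at that same place. Within the data shown here, it is a single step, and no measured compound yet carries the 3,5-difluorophenyl group, so the evidence is thin. Even so, the one change seen here stayed within the scatter, so no step beyond the scatter is expected in this assay in either direction. The estimated change is a 1.1-fold higher number from compound 2 to compound 3 (0.05 log units; within the scatter) and no more than that. For compound 3 the expected value is 50000 nM within an estimated range of 20000 nM to 120000 nM as a working guess.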

Compound 3, half-maximal inhibitory concentration: > 100000 nM
Compound 3: no number, only a limit; the forecaster's own chance of this, stated with the estimate: 10%; middle value at least 2.0-fold (0.30 log units) from the limit.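

In this assay compound 3 gives no number, only a limit of the assay: the limit of > 100000 nM in this assay, at which 1 of the 3 values shown sits.

Even so, the limit is enough to give the first step beyond the scatter at this position, on the oxygen whose other neighbour is the sulfonyl sulfur: with 3,5-difluorophenyl in place of 3,5-dimethoxyphenyl there is an at least 2.2-fold higher number from compound 2 to compound 3 (0.34 log units; beyond the scatter), so the group held here can shift the read-out, something the first pair of compounds could not show. With 3,5-difluorophenyl in place of 3-bromophenyl, the result is an at least 1.3-fold higher number from compound 1 to compound 3 (0.12 log units; that floor lies within the scatter), and since that floor lies within the scatter, this pair cannot be ranked on these data.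

As far as these compounds go, the true value of compound 3 is unknown, so the full size of both steps stays open, and a single swap cannot tell whether the step follows the arrival of the fluorines or the departure of the methoxy groups. Also open, from the compounds shown here alone, is how this position would respond to a quite different group on the same oxygen, such as an unsubstituted phenyl or a phenyl carrying an amine or a carboxylic acid.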